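Swapping the benzyl amide of compound 1 for quinolin-8-yl

The source may hold more compounds than are shown below. What is called first, only, known or untested is meant among the compounds shown, and "the series" means these compounds.

Compound 1 `CN(C)c1ccc(C(=O)N[C@@H](CCCCCC(=O)NO)C(=O)NCc2ccccc2)cc1` is one of three hydroxamic acids sharing the same core and differing in the group on the carbonyl carbon. In a functional assay on NFF cells (Homo sapiens) for antiproliferative activity (a higher number here means a weaker inhibitor, a lower number a stronger inhibitor), compound 1 gives 12000 nM, the highest number of the three. Compound 2 `O=C(CCCCC[C@H](NC(=O)c1ccc(C(F)(F)F)cc1)C(=O)NCc1ccccc1)NO` gives 1610 nM and compound 3 `O=C(CCCCC[C@H](NC(=O)c1cc2c(Br)cccc2[nH]1)C(=O)NCc1ccccc1)NO` gives 1940 nM; the step of a 7.5-fold lower number from compound 1 to compound 2 (0.87 log units; beyond the scatter) and the step of a 6.2-fold lower number from compound 1 to compound 3 (0.79 log units; beyond the scatter) both lie beyond the scatter, while the step of a 1.2-fold higher number from compound 2 to compound 3 (0.08 log units; within the scatter) does not.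

Compound 4 `CN(C)c1ccc(C(=O)N[C@@H](CCCCCC(=O)NO)C(=O)Nc2cccc3cccnc23)cc1` differs from compound 1 at the other end of the molecule: quinolin-8-yl in place of benzyl on an amide-type nitrogen. Among the measured compounds shown here, none of the measured steps touches this amide-type nitrogen, so the three measured compounds say nothing direct about how this change plays out. Without a step that bears on it, the expectation for compound 4 is anchored to compound 1 and carries a wide range: the expected step is a 1.2-fold lower number from compound 1 to compound 4 (0.08 log units; within the scatter), a change not confidently beyond the scatter. Compound 4 is therefore estimated at 10000 nM, between 3000 nM and 35000 nM.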

Compound 4, half-maximal inhibitory concentration: 570 nM
For compound 4 the middle estimate is 18-fold (1.24 log units) above the measured one, and the stated range ends above it.
By their numbers in this assay, from the lowest: compound 4; then compounds 2 and 3 (each within the scatter of the next); then compound 1.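

At the amide-type nitrogen, quinolin-8-yl in place of benzyl gives a 21-fold lower number from compound 1 to compound 4 (1.32 log units; beyond the scatter) in this assay. The earlier compounds shown here changed only the group on the carbonyl carbon, with modest steps of a 7.5-fold lower number from compound 1 to compound 2 (0.87 log units; beyond the scatter) and a 6.2-fold lower number from compound 1 to compound 3 (0.79 log units; beyond the scatter), so this large step shows that the other end of the molecule can move the read-out further than either of those changes. No available evidence explains this gain.

The change replaces one aromatic ring with two and adds a ring nitrogen, and a naphthalen-1-yl or phenyl group on the same nitrogen would help to show which of these differences matters. From the compounds shown here alone, it also remains open whether quinolin-8-yl gives a similar step when the dimethylamino group is replaced by trifluoromethyl, as in compound 2, or when the 4-(dimethylamino)phenyl group is replaced by 4-bromo-1H-indol-2-yl, as in compound 3.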